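Swapping the Sulfonyl Aryl Group for a Bromothiophene

This account rests on a few compounds, and the source may have more. Where it says the series, first, only, none or still open, it means among the compounds named here.

Of the compounds shown here, three sharing one core have been tested in a functional assay on HepG2 cells for inhibition of squalene monooxygenase (Homo sapiens); a lower number here means a stronger inhibitor, a higher number a weaker inhibitor. Compound 1 `CCN(C/C=C/C#CC(C)(C)C)Cc1cccc(OCCN(C)S(=O)(=O)c2ccc(F)cc2)c1` gives 255 nM. Compound 2 `CCN(C/C=C/C#CC(C)(C)C)Cc1cccc(OCCN(C)S(=O)(=O)c2ccc(C#N)cc2)c1` gives 200 nM. Compound 3 `CCN(C/C=C/C#CC(C)(C)C)Cc1cccc(OCCN(C)S(=O)(=O)c2ccc(Br)s2)c1` gives 390 nM. Compound 2 holds the lowest of the three numbers, but the steps that separate it from the other two are a 1.3-fold lower number from compound 1 to compound 2 (0.11 log units; within the scatter) and a 2.0-fold higher number from compound 2 to compound 3 (0.29 log units; within the scatter), so none of the three can be told apart with confidence in this assay.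

The next compound, compound 4 `CCN(C/C=C/C#CC(C)(C)C)Cc1cccc(OCCN(C)S(=O)(=O)c2cc(Br)cs2)c1`, differs from compound 2 in one place: 4-bromothiophen-2-yl in place of 4-cyanophenyl on a sulfonyl sulfur. Among the compounds with values here, two measured steps bear on this change. Exchanging the 4-fluorophenyl of compound 1 for a 5-bromothiophen-2-yl gave a 1.5-fold higher number from compound 1 to compound 3 (0.18 log units; within the scatter), and exchanging the 4-cyanophenyl of compound 2 for the same group gave a 2.0-fold higher number from compound 2 to compound 3 (0.29 log units; within the scatter). Both point the same way, yet both stay within the scatter. Within the data shown here, the group entering compound 4 carries its bromine on a different carbon of the thiophene than in compound 3, and no measured pair shows what that shift does.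

The expectation for compound 4 is therefore a modest rise in number, a 1.8-fold higher number from compound 2 to compound 4 (0.24 log units; within the scatter), mirroring compound 3. Compound 4 is estimated at 350 nM, within a range of 150 nM to 800 nM.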

Compound 4, half-maximal inhibitory concentration: 300 nM
For compound 4 the middle estimate is 1.2-fold (0.07 log units) above the measured one; low and high end bracket the measured number.
By their numbers in this assay, from the lowest: compounds 2, 1, 4 and 3 (each within the scatter of the next).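

Shifting the bromine around the thiophene ring, with 4-bromothiophen-2-yl in place of 5-bromothiophen-2-yl on the sulfonyl sulfur, gives in this assay a 1.3-fold lower number from compound 3 to compound 4 (0.11 log units; within the scatter) and is the first measured look at that shift; the two bromothiophene isomers cannot be told apart here. The comparisons with the six-membered aromatic rings read the same way, with a 1.5-fold higher number from compound 2 to compound 4 (0.18 log units; within the scatter) against the nitrile-bearing ring and a 1.2-fold higher number from compound 1 to compound 4 (0.07 log units; within the scatter) against the fluorine-bearing ring, so all four groups on the sulfonyl sulfur now lie within the scatter of one another and this position has tolerated every change shown so far. No other measurement is at hand that could explain these numbers.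

On these data alone, whether a plain phenyl, a thiophene without bromine, or an aromatic ring carrying an amine or a carboxylic acid on the sulfonyl sulfur would give a number beyond the scatter remains open. As far as these compounds go, the rest of the shared core is identical in all four compounds, so it is also open whether these small steps would hold with a longer chain in place of the methyl on the sulfonamide nitrogen.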